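The source may report more compounds than this note shows. Statements on the series, on what has been measured and on what is new or still open speak of the compounds shown alone.

Compound 1 `COc1cccc(N2CCN(CC(=O)N3CCN(c4nnc(-c5ccccc5)c(-c5ccccc5)n4)CC3)CC2)c1` is measured in an ADME assay on NIH3T3 cells (Mus musculus) for cytotoxicity, read by MTT assay, with a stated time of 24 h (on this read-out lower numbers stand for stronger inhibition and higher numbers for weaker inhibition), and compound 1 gives 361000 nM. Compound 2 `O=C(CN1CCN(c2cccc(Cl)c2)CC1)N1CCN(c2nnc(-c3ccccc3)c(-c3ccccc3)n2)CC1` differs from compound 1 by chloro in place of methoxy on an aromatic carbon, and in this assay compound 2 gives 178000 nM, a step of a 2.0-fold lower number from compound 1 to compound 2 (0.31 log units; beyond the scatter). Compound 3 `COc1ccc(-c2nnc(N3CCN(C(=O)CN4CCN(c5ccccc5OC)CC4)CC3)nc2-c2ccc(OC)cc2)cc1` has a core that differs from that of compound 1 in more than one place, and the difference between the two cores is not broken down here. In this assay compound 3 gives only a limit, > 821000 nM, and no number. That limit is the limit of > 821000 nM in this assay, at which 1 of the 3 values shown sits.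

Compound 4 `COc1ccc(-c2nnc(N3CCN(C(=O)CN4CCN(c5ccccc5Cl)CC4)CC3)nc2-c2ccc(OC)cc2)cc1` differs from compound 3 by chloro in place of methoxy on an aromatic carbon. This is the same kind of change as that from compound 1 to compound 2, but the place differs: in compound 2 the chloro sits meta to a large group, whereas in compound 4 it sits ortho to a large group. Because compound 3 gives only a limit > 821000 nM, the starting point for compound 4 is uncertain. The step expected for compound 4 is an at least 1.1-fold lower number from compound 3 to compound 4 (0.06 log units; that floor lies within the scatter), resting on the step from compound 1 to compound 2 of a 2.0-fold lower number from compound 1 to compound 2 (0.31 log units; beyond the scatter). Compound 4 is therefore estimated at 700000 nM, between 300000 nM and 2000000 nM.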

Compound 4, half-maximal inhibitory concentration: > 814000 nM
Compound 4: a limit, no number; the forecaster's own chance of this, stated with the estimate: 55%; middle value at least 1.1-fold (0.06 log units) away from the limit.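

In this assay, among the compounds shown here, compound 3 and compound 4 both give only limits and no numbers, so no step between them can be read. The compounds shown leave open whether 2-methoxyphenyl to 2-chlorophenyl changes the read-out at all on the core of compound 3, as chloro in place of methoxy did on the core of compound 1 (a 2.0-fold lower number from compound 1 to compound 2 (0.31 log units; beyond the scatter)).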